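This account rests on a few compounds, and the source may have more. Where it says the series, first, only, none or still open, it means among the compounds named here.

Of the compounds shown here, two sharing one core have been measured in an assay on isolated protein for inhibition of aldehyde dehydrogenase 1A1 (Homo sapiens), read by spectrophotometry, tested at 10 uM; on this read-out higher numbers stand for more inhibition at the one concentration tested (going by the name of the read-out) and lower numbers for less inhibition. Compound 1 `Cc1cccc(Cn2c(CN3CCN(C(=O)C4CCCC4)CC3)nc3ccccc32)c1` gives 67.5% in this assay. Compound 2 `Cc1ccc(Cn2c(CN3CCN(C(=O)C4CC4)CC3)nc3ccccc32)cc1` gives 51.5% in this assay. Of the two numbers, compound 2 stands lowest; its nearest neighbour, compound 1, lies higher by a gap beyond the usual scatter of repeated measurements. For the measured compounds named here, compound 1 and compound 2 differ in more than one place, so no single step between them can be read off, and their two values are all they show.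

Compound 3 `Cc1ccccc1Cn1c(CN2CCN(C(=O)C3CC3)CC2)nc2ccccc21` has not yet been measured. It differs from compound 2 in one place: 2-methylphenyl in place of 4-methylphenyl on a saturated chain carbon bound to an aromatic nitrogen. Going by the values given here, no measured pair shows what this change does, so any expectation rests on compound 2 alone. A step of roughly the size of the scatter, in either direction, is the reasonable expectation. Compound 3 is therefore estimated at 50% in this assay, with a range from 30% to 70%. That amounts to an expected step of a number 1.5 percentage points lower from compound 2 to compound 3 (within the scatter).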

Compound 3, a percentage reported as inhibition, at one concentration (the size of the read-out at that concentration, not a potency): 29.1%
For compound 3 the middle estimate is 20.9 percentage points above the measured one, outside the stated range (below it).
By their numbers in this assay, from the lowest: compound 3; then compound 2; then compound 1.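

On a saturated chain carbon bound to an aromatic nitrogen, replacing 4-methylphenyl with 2-methylphenyl gives a number 22.4 percentage points lower from compound 2 to compound 3 (beyond the scatter) in this assay. The two groups have the same atoms, joined differently, so this position is sensitive to the arrangement of the group and not only to its composition: in this pair, inhibition at the one concentration tested falls by more than the usual scatter with no atom added or removed. Nothing available explains why this rearrangement lowers the number, so the finding remains an observation about this one pair.

Steps from compound 1 to compound 2 or compound 3 cannot be read because compound 1 differs from each in more than one place, so it remains open whether the same swap would have a similar effect alongside the other amide group of compound 1. The compounds shown also do not reveal how this position would respond to a phenyl ring with no methyl group, a methoxy group in place of the methyl, or a pyridine ring in place of the phenyl ring.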